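The source may report more compounds than this note shows. Statements on the series, on what has been measured and on what is new or still open speak of the compounds shown alone.

The three measured compounds share one core and differ only in the group carried on a carbonyl carbon. Compound 1 `N#CC1(NC(=O)[C@@H]2C[C@@H](S(=O)(=O)c3ccccc3)C[C@H]2C(=O)N2CC3CCC(C2)O3)CC1` gives 1 nM in an assay on isolated protein for inhibition of cathepsin S (Homo sapiens), read by fluorescence, with a stated time of 20 min; on this read-out lower numbers stand for stronger inhibition and higher numbers for weaker inhibition. Compound 2 `N#CC1(NC(=O)[C@@H]2C[C@@H](S(=O)(=O)c3ccccc3)C[C@H]2C(=O)N2CCNCC2)CC1` gives 11 nM in this assay, and compound 3 `N#CC1(NC(=O)[C@@H]2C[C@@H](S(=O)(=O)c3ccccc3)C[C@H]2C(=O)N2CCS(=O)(=O)CC2)CC1` gives 4 nM. Compound 3 thus stands second highest of the three: the step of a 2.8-fold lower number from compound 2 to compound 3 (0.44 log units; beyond the scatter) is modest, while the step of a 4.0-fold higher number from compound 1 to compound 3 (0.60 log units; beyond the scatter) is also modest, and the largest step among them is an 11-fold higher number from compound 1 to compound 2 (1.04 log units; beyond the scatter).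

Compound 4 `N#CC1(NC(=O)[C@@H]2C[C@@H](S(=O)(=O)c3ccccc3)C[C@H]2C(=O)N2CCCC2)CC1` differs from compound 3 by pyrrolidin-1-yl in place of 1,1-dioxothiomorpholin-4-yl on a carbonyl carbon. All three measured steps concern exchanges of the group on this carbonyl carbon, and they range from modest to large, so a change here can move the number either way. With nothing measured for the ring that enters, the step of no change at the digits printed from compound 3 to compound 4 (within the scatter) is expected to stay small, and compound 4 is estimated at 4 nM, within a range from 1.2 nM to 14 nM.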

Compound 4, half-maximal inhibitory concentration: 2 nM
Compound 4: middle estimate off by 2.0-fold (0.30 log units), on the high side; the range from low to high includes it.
By their numbers in this assay, from the lowest: compounds 1, 4 and 3 (each within the scatter of the next, the first and the last beyond it); then compound 2.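

In this assay the pyrrolidin-1-yl group stands in for 1,1-dioxothiomorpholin-4-yl with a 2.0-fold lower number from compound 3 to compound 4 (0.30 log units; within the scatter) and for the larger group of compound 1 with a 2.0-fold higher number from compound 1 to compound 4 (0.30 log units; within the scatter) so on this carbonyl carbon a smaller ring with no hydrogen-bond acceptors gives no step beyond the scatter from either. Against piperazin-1-yl the same ring gives a 5.5-fold lower number from compound 2 to compound 4 (0.74 log units; beyond the scatter) and this leaves compound 2 as the only one of the four whose steps to all the others lie beyond the scatter. No evidence is available on why the numbers fall this way.

The compounds shown leave open whether a smaller azetidin-1-yl ring or an open diethylamino group on this carbonyl carbon would stay in the same range. They also leave open whether the higher number of compound 2 would persist with a methyl group on the second nitrogen of its piperazine ring.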